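The source may hold more compounds than are shown below. What is called first, only, known or untested is meant among the compounds shown, and "the series" means these compounds.

Measured compounds in this study:
Compound 1, `CC(C)N(Cc1cccc(OCCCCCC(=O)O)c1)C(=O)c1ccc(-c2cccc(O)c2)cc1`: > 26000 nM
Compound 2, `CC(C)N(Cc1cccc(OCCCCCC(=O)O)c1)C(=O)c1ccc(-c2cccc(OC(F)(F)F)c2)cc1`: > 26000 nM
Compound 3, `CCOC(=O)CCCCCOc1cccc(CN(C(=O)c2ccc(-c3cccc(O)c3)cc2)C(C)C)c1`: > 26000 nM

All three were tested in an ADME assay on HEK293 cells (Homo sapiens) for cytotoxicity, read by CellTiter-Glo and resazurin assay, with a stated time of 72 h; on this read-out lower numbers stand for an effect already at smaller amounts and higher numbers for an effect only at larger amounts of compound. In this assay compound 1 gives > 26000 nM, which is a limit of the assay and not a number. Compound 2 likewise gives > 26000 nM, again a limit. Compound 3 gives > 26000 nM, also a limit. Compound 1 and compound 2 differ by trifluoromethyl in place of hydrogen on an oxygen on an aromatic ring, and this gives a step that the two limits leave unreadable from compound 1 to compound 2. Compound 1 and compound 3 differ in their cores by ethyl in place of hydrogen on an oxygen next to a carbonyl group, and this gives a step that the two limits leave unreadable from compound 1 to compound 3. The sizes of both steps cannot be read because of the limit of > 26000 nM in this assay, at which 3 of the 3 values shown sit.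

Compound 4, `CCOC(=O)CCCCCOc1cccc(CN(C(=O)c2ccc(-c3cccc(OC(F)(F)F)c3)cc2)C(C)C)c1`, has not yet been measured in this assay. It differs from compound 3 by trifluoromethyl in place of hydrogen on an oxygen on an aromatic ring, the same change as that from compound 1 to compound 2, since the surroundings of the place are the same. Since every measured value sits at the limit, the expected step is a step that the limit leaves unreadable from compound 3 to compound 4, resting on the measured values of compound 1, compound 2 and compound 3. Compound 4 is therefore expected to give about 40000 nM, most likely again reported only as a limit.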

Compound 4, half-maximal effective concentration: > 26000 nM
Compound 4 gave a limit, no number (the forecaster's own chance of this, stated with the estimate: 85%); the middle value lies beyond the limit too.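

Neither the step from compound 3 to compound 4 nor the step from compound 2 to compound 4 can be read, because all the results stop at the same assay limit and give no actual numbers: the limit of > 26000 nM in this assay, at which 4 of the 4 values shown sit.

The compounds shown leave open at what amount any of the four would show an effect in this assay, and so whether either change alters that amount at all.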